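Series notes: aryl change on the carbon double-bonded to nitrogen

The source may report more compounds than this note shows. Statements on the series, on what has been measured and on what is new or still open speak of the compounds shown alone.

Three measured compounds share one core and differ only in the aromatic group on a carbon with a double bond to nitrogen. Compound 1 `CN(C)CCn1cnnc1-c1cc(Oc2ccc(NC(=O)N/N=C/c3ccccc3O[N+](=O)[O-])cc2F)ccn1` gives 1200 nM in a functional assay on A549 cells (Homo sapiens) for cytotoxicity, read by MTT assay, with a stated time of 72 h; on this read-out lower numbers stand for stronger inhibition and higher numbers for weaker inhibition. Compound 2 `CN(C)CCn1cnnc1-c1cc(Oc2ccc(NC(=O)N/N=C/c3ccc(F)cc3F)cc2F)ccn1` gives 1870 nM in this assay, and compound 3 `CN(C)CCn1cnnc1-c1cc(Oc2ccc(NC(=O)N/N=C/c3cccc(Br)c3)cc2F)ccn1` gives 970 nM. Among these three numbers compound 1 holds the second highest; compound 3 lies nearest with a 1.2-fold lower number from compound 1 to compound 3 (0.09 log units; within the scatter) and compound 2 furthest with a 1.6-fold higher number from compound 1 to compound 2 (0.19 log units; within the scatter). The remaining step is a 1.9-fold lower number from compound 2 to compound 3 (0.29 log units; within the scatter). All three steps fall within the scatter, so the three numbers cannot be set in order.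

Compound 4 `COc1ccc(/C=N/NC(=O)Nc2ccc(Oc3ccnc(-c4nncn4CCN(C)C)c3)c(F)c2)cc1O` is not yet measured. Relative to compound 1 it carries 3-hydroxy-4-methoxyphenyl in place of 2-(nitrooxy)phenyl on a carbon with a double bond to nitrogen. Every measured step in the set exchanges the aromatic group at this same place, and none of them moved the number beyond the scatter, so the same outcome is expected here: no step beyond the scatter in this assay, in either direction. The number for compound 4 is estimated at 1200 nM, with a range of 500 nM to 2900 nM. This estimate means no change at the digits printed from compound 1 to compound 4 (within the scatter), which is expected to stay within the scatter.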

Compound 4, half-maximal inhibitory concentration: > 100000 nM
Compound 4 ended at the assay's limit (the forecaster's own chance of this, stated with the estimate: 3%); middle value at least 83-fold (1.92 log units) away from the limit.
By their numbers in this assay, from the lowest: compounds 3, 1 and 2 (each within the scatter of the next). At a limit, above all of these: compound 4.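

For compound 4 the entry > 100000 nM in this assay is a limit of the assay and not a number. The place on a carbon with a double bond to nitrogen had shown no step beyond the scatter among 2-(nitrooxy)phenyl, 2,4-difluorophenyl and 3-bromophenyl, but it is not indifferent to every aromatic group: with 3-hydroxy-4-methoxyphenyl the steps are an at least 83-fold higher number from compound 1 to compound 4 (1.92 log units; beyond the scatter), an at least 53-fold higher number from compound 2 to compound 4 (1.72 log units; beyond the scatter) and an at least 100-fold higher number from compound 3 to compound 4 (2.01 log units; beyond the scatter), all large. The rest of the structure is shared, so these steps go with this one aromatic group, the only one of the four that reaches the limit: the limit of > 100000 nM in this assay, at which 1 of the 4 values shown sits.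

The hydroxy and methoxy groups occur here only together, so the compounds shown leave open which of them, or whether only the pair, goes with the step; 3-hydroxyphenyl and 4-methoxyphenyl at this place would separate the two. Also open, going by these compounds, is whether another group on the ring, such as an amine in 3-aminophenyl or a carboxylic acid in 3-carboxyphenyl, would stay with compounds 1, 2 and 3 or move towards compound 4.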